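Swapping Methyl for Hydroxy in Compound 3

The compounds below may be only part of what the source reports. "The series", "measured", "known", "first", "only" and "open" are said of these compounds alone.

Three compounds with a shared core have been taken into an ADME assay on TZM cells (Homo sapiens) for cytotoxicity, read by CellTiter-Glo, with a stated time of 48 h; a lower number here means that less compound is tolerated, a higher number that more compound is tolerated. For compound 1 `COc1ccc(C2=Cc3ccc(F)cc3C(CC(C)=O)N2c2ccc(C#N)cc2)cc1` the entry reads "not determined" (no result reported), so it offers no number for comparison. Compound 2 `COc1ccc(C2=Cc3ccc([N+](=O)[O-])cc3C(CC(C)=O)N2c2ccc(C)cc2)cc1` gives 10600 nM. Compound 3 `COc1ccc(C2=Cc3ccc(F)cc3C(CC(=O)CO)N2c2ccc(C)cc2)cc1` gives 23700 nM, the higher of the two available numbers, and its gap to compound 2 lies beyond the scatter. However, compound 2 and compound 3 differ in more than one place, so that gap cannot be assigned to any single group.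

The next compound, compound 4 `COc1ccc(C2=Cc3ccc(F)cc3C(CC(=O)CO)N2c2ccc(O)cc2)cc1`, departs from compound 3 in one place only: hydroxy in place of methyl on an aromatic carbon. This puts hydroxy in place of methyl on an aromatic carbon, para to a large group, turning 4-methylphenyl into 4-hydroxyphenyl. Within the data shown here, no pair of measured compounds isolates a single change, so the data give no direct guide to the size of this one. In this assay the expectation is therefore modest: no step beyond the scatter, with a slight lean toward a lower number. The estimated change is a 1.3-fold lower number from compound 3 to compound 4 (0.12 log units; within the scatter). Compound 4 is expected at 18000 nM, with an estimated range of 7000 nM to 45000 nM.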

Compound 4, half-maximal cytotoxic concentration: 47700 nM
Estimate against measurement, compound 4: 2.7-fold (0.42 log units) below; the whole stated range lies below it.
By their numbers in this assay, from the lowest: compound 2; then compounds 3 and 4 (each within the scatter of the next).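

In this assay, among these compounds, the exchange of methyl for hydroxy on the aromatic carbon gives a 2.0-fold higher number from compound 3 to compound 4 (0.30 log units; within the scatter), and this is the first step that can be read for a single change, since the earlier compounds with numbers differ in more than one place. It shows that, with the rest of the structure held constant, going from 4-methylphenyl to 4-hydroxyphenyl adds one hydrogen-bond donor and one hydrogen-bond acceptor at this position without moving the number beyond the usual scatter, so this one pair gives no sign that cytotoxicity here depends on which of these two groups is present. No measured evidence is available to explain the size of this step.

What the compounds shown leave open is whether a larger departure at the same position, such as an amine or a carboxylic acid, would produce a step beyond the scatter. From the compounds shown here alone, it also remains open whether the exchange of methyl for hydroxy would give a similar step on a core carrying different groups elsewhere.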